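Hexyl chain extension on the pentyl hydroxyethyl purine analogue

The compounds below may be only part of what the source reports. "The series", "measured", "known", "first", "only" and "open" are said of these compounds alone.

Measured so far:
compound 1, `CCCCCC(CCO)n1cnc2c(Cl)ncnc21`, > 50000 nM
compound 2, `CCCCCC(CCO)n1cnc2c(OC)ncnc21`, > 50000 nM

In a functional assay on SW480 cells (Homo sapiens) for antiproliferative activity, read by MTT assay, with a stated time of 48 h (on this read-out lower numbers stand for stronger inhibition and higher numbers for weaker inhibition), compound 1 gives > 50000 nM, which is a limit of the assay and not a number. In this assay compound 2 gives > 50000 nM, again a limit rather than a number. The one step between measured compounds, a step that the two limits leave unreadable from compound 1 to compound 2, is therefore unreadable, and compound 2 stands only at the limit, with both shown values sitting there (the limit of > 50000 nM in this assay, at which 2 of the 2 values shown sit).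

Compound 3, `CCCCCCCCCCCC(CCO)n1cnc2c(OC)ncnc21`, differs from compound 2 by hexyl in place of hydrogen on a saturated chain carbon, six bonds along the chain from an aromatic nitrogen. Within the data shown here, no measured step concerns a chain of this kind, so nothing reads on the size or direction of the change. Compound 3 is expected to stay near the limit, a step of an at least 1.2-fold lower number from compound 2 to compound 3 (0.09 log units; that floor lies within the scatter). The estimate for compound 3 is 40000 nM, within 8000 nM to 200000 nM.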

Compound 3, half-maximal inhibitory concentration: 9700 nM
Compound 3: middle estimate off by 4.1-fold (0.62 log units), on the high side, within the range that was stated.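

In this assay, among these compounds, hexyl in place of hydrogen on a saturated chain carbon, six bonds along the chain from an aromatic nitrogen, gives an at least 5.1-fold lower number from compound 2 to compound 3 (0.71 log units; beyond the scatter), the only readable step. This chain position therefore responds to a change in this assay, whereas the step from chloro to methoxy on the aromatic carbon cannot be read. Compound 3 is the only compound shown with a value off the limit: the limit of > 50000 nM in this assay, at which 2 of the 3 values shown sit.

The step starts from a limit, so only its smallest possible size is known, and one chain extension gives no trend with chain length. On these data alone, whether a shorter chain such as propyl, a longer chain such as decyl, or a chain ending in an amine would give a similar step remains open, as does the effect of chloro in place of methoxy on the longer chain.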